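Extending methoxymethyl to propoxymethyl on compound 3

The compounds below may be only part of what the source reports. "The series", "measured", "known", "first", "only" and "open" are said of these compounds alone.

Measured so far (a functional assay on MES-SA/Dx5 cells (Homo sapiens) for inhibition, with a stated time of 72 h, in the presence of a further agent that is not named here; on this read-out lower numbers stand for stronger inhibition and higher numbers for weaker inhibition):
- compound 1 `Oc1c(CN2CCCC2)cc(Cl)c2cccnc12` (3210 nM; 3160 nM (2 entries))
- compound 2 `COCc1cc(CN2CCCC2)c(O)c2ncccc12` (3550 nM)
- compound 3 `COCc1cc(CN2CCCCC2)c(O)c2ncccc12` (7590 nM)

The repeat entries for compound 1 (the several entries of compound 1 in this assay, 3210 nM; 3160 nM (2 entries)) agree closely. Compound 3 (7590 nM) carries the highest number in the set, and its nearest neighbour is compound 2 (3550 nM).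

The next compound to be read is compound 4 (`CCCOCc1cc(CN2CCCCC2)c(O)c2ncccc12`). Its change is ethyl in place of hydrogen on a saturated chain carbon bound to an oxygen on a saturated carbon (methoxymethyl to propoxymethyl).

Within the data shown here, only one measured step bears on this, and only indirectly. It is a 2.1-fold higher number from compound 2 to compound 3 (0.33 log units; beyond the scatter) (piperidin-1-yl in place of pyrrolidin-1-yl), a modest step just beyond the scatter. Among the measured compounds shown here, that step lies elsewhere in the molecule, so no measured compound shows what the ether chain does on its own. With so little to go on, a step of about that modest size is the largest one that can reasonably be allowed for, in either direction. As far as these compounds go, no step beyond the scatter is expected in this assay, and the direction stays open.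

The expected change is a 1.2-fold lower number from compound 3 to compound 4 (0.07 log units; within the scatter) in this assay on this reasoning.

For compound 4 the estimated value is 6500 nM (expected range 3000 nM to 13000 nM).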

Compound 4, half-maximal inhibitory concentration: 2400 nM
The estimate for compound 4 lay 2.7-fold (0.43 log units) above the measured number, and the stated range ends above it.
By their numbers in this assay, from the lowest: compounds 4 and 2 (each within the scatter of the next); then compound 3.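

In this assay, the ether chain now has a reading of its own: ethyl in place of hydrogen on a saturated chain carbon bound to an oxygen on a saturated carbon gives a 3.2-fold lower number from compound 3 to compound 4 (0.50 log units; beyond the scatter). Among these compounds, the earlier compounds offered only one single-place step, piperidin-1-yl in place of pyrrolidin-1-yl, with a 2.1-fold higher number from compound 2 to compound 3 (0.33 log units; beyond the scatter), so they said nothing about this position; the new step shows that the position responds to the change, and that with piperidin-1-yl held constant, propoxymethyl gives the lower number than methoxymethyl. The one repeat check available in the series supports taking this modest step at face value: the several entries of compound 1 in this assay, 3210 nM; 3160 nM (2 entries)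

As far as these compounds go, a single pair fixes no trend along the chain, so it remains open whether a longer chain such as butoxymethyl or pentoxymethyl would lower the number further or reverse the step. Also open, from the compounds shown here alone, are how propoxymethyl reads with pyrrolidin-1-yl in place of piperidin-1-yl, and how an amine or a carboxylic acid at the end of the ether chain would read in this assay.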